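Swapping the Ring on a Tetrahydroxybutyl Compound

A few compounds are considered here, and "the series" means these few. Any claim that something is new, unique, unknown or untested is made for them only; others in the source may bear on it.

Compound 1 `CC(=O)c1cccc([C@@H](O)[C@H](O)[C@H](O)CO)n1`: 10500 ng.h/mL
Compound 2 `CC(=O)c1ncc([C@@H](O)[C@H](O)[C@H](O)CO)s1`: 668 ng.h/mL
Compound 3 `OC[C@@H](O)[C@@H](O)[C@H](O)c1c[nH]c(-c2cscn2)n1`: 1570 ng.h/mL

All three numbers come from an ADME assay on the whole organism (plasma, strain 129/SvEvBrd x C57BL/6) for pharmacokinetics, with Mus musculus as the target, at a dose of 10 mg/kg by the oral route; a lower number here means less compound in the circulation, a higher number more compound in the circulation at the dose given. Compound 3, at 1570 ng.h/mL, is the second highest of the three. Compound 2 lies lower at 668 ng.h/mL, and compound 1 lies higher at 10500 ng.h/mL. Both gaps are beyond the usual scatter.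

The next compound to be measured is compound 4 `OC[C@@H](O)[C@@H](O)[C@H](O)c1c[nH]c(-c2ncccn2)n1`. It differs from compound 3 in one place: pyrimidin-2-yl stands in place of 1,3-thiazol-4-yl on an aromatic carbon, between two ring nitrogen atoms (pyrimidin-2-yl in place of 1,3-thiazol-4-yl on an aromatic carbon). The rest of the structure stays the same.

For the measured compounds named here, no two measured compounds differ in just one place, so the data show nothing directly about what such a swap does. The wide spread of the measured values, from compound 2 at 668 ng.h/mL to compound 1 at 10500 ng.h/mL, also argues for caution. With no evidence for a direction, no change beyond the scatter is expected in this assay. The expected step is a 1.1-fold lower number from compound 3 to compound 4 (0.05 log units; within the scatter). For compound 4 the estimated value is 1400 ng.h/mL, with an expected range of 450 ng.h/mL to 4500 ng.h/mL.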

Compound 4, area under the concentration-time curve: 799 ng.h/mL
For compound 4 the middle estimate is 1.8-fold (0.24 log units) above the measured one; the measured number falls inside the stated range.
By their numbers in this assay, from the lowest: compounds 2, 4 and 3 (each within the scatter of the next, the first and the last beyond it); then compound 1.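

For the compounds shown here, this is the first pair that differs in only one place, and it gives a direct reading of a ring swap on an aromatic carbon between two ring nitrogen atoms. In this assay, replacing 1,3-thiazol-4-yl with pyrimidin-2-yl gives a 2.0-fold lower number from compound 3 to compound 4 (0.29 log units; within the scatter), so a five-membered aromatic ring and a six-membered one, with equal counts of hydrogen-bond donors and acceptors, cannot be told apart here by exposure in the circulation. No measurement shown here offers an explanation for this result.

From the compounds shown here alone, it remains open whether a phenyl ring, an amine, a carboxylic acid or a short alkyl chain at this same carbon would also stay within the scatter, or would move the number clearly up or down. Compounds 1 and 2 differ from compounds 3 and 4 in more than one place, so this swap says nothing about which structural feature separates their numbers.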